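A few compounds are considered here, and "the series" means these few. Any claim that something is new, unique, unknown or untested is made for them only; others in the source may bear on it.

Compound 2, whose structure is `COc1ccc(F)cc1CNCCCNc1ccnc2cc(Oc3ccccc3)ccc12`, is one of two measured compounds in this set. In an ADME assay for permeability, using PAMPA, with a stated time of 30 min, at pH 7.4 (on this read-out lower numbers stand for lower permeability and higher numbers for higher permeability), compound 2 gives 317 10^-6 cm/s. Its only measured neighbour is compound 1, with the structure `COc1cccc(Oc2ccc3c(NCCCNCc4cc(F)ccc4OC)ccnc3c2)c1`, which in this assay gives 317 10^-6 cm/s; the step from compound 1 to compound 2 reads no change at the digits printed from compound 1 to compound 2 (within the scatter), so compound 2 stands level with compound 1 at the digits shown, with nothing between them beyond the scatter.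

Compound 3, the unmeasured compound, has the structure `COc1ccc(F)cc1CNCCCNc1ccnc2cc(Oc3ccccc3OC)ccc12`. Its difference from compound 2 is methoxy in place of hydrogen on an aromatic carbon. Read one bond further out, the change is phenoxy to 2-methoxyphenoxy, the methoxy sitting on an aromatic carbon of a six-membered carbon-only ring, ortho to a large group.

Among the compounds with values here, the one step that bears on this is the one from compound 1 to compound 2, where taking a methoxy off an aromatic carbon left the permeability unchanged, at no change at the digits printed from compound 1 to compound 2 (within the scatter). Putting a methoxy onto an aromatic carbon is therefore expected to give no step beyond the scatter in this assay, with the expected step from compound 2 to compound 3 being no change at the digits printed from compound 2 to compound 3 (within the scatter). For compound 3 the estimated value in this assay is 317 10^-6 cm/s, expected to lie between 160 10^-6 cm/s and 630 10^-6 cm/s.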

Compound 3, apparent permeability in the ADME assay: 317 10^-6 cm/s
The estimate for compound 3 equals the measured number at the digits printed; low and high end bracket the measured number.
By their numbers in the ADME assay, from the lowest: compounds 1, 2 and 3 (each within the scatter of the next).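

In the ADME assay the new compound adds a second placing of the methoxy on the phenoxy ring: putting it on the unsubstituted ring gives no change at the digits printed from compound 2 to compound 3 (within the scatter) and, at the position ortho to a large group, the swap of 3-methoxyphenyl for 2-methoxyphenyl gives no change at the digits printed from compound 1 to compound 3 (within the scatter) in this set. The same methoxy can now also be followed in a second read-out, since in a physicochemical assay for solubility, with a stated time of 18 h, at pH 7.4 (a lower number here means a less soluble compound, a higher number a more soluble compound), compound 2 gives 14500 nM and compound 3 gives 14500 nM for a step that reads no change at the digits printed from compound 2 to compound 3 (within the scatter) on this pair. No measurement is at hand that would explain why these steps are so flat.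

The compounds shown carry only hydrogen or methoxy on this ring, so what an amine, a carboxylic acid or a longer chain such as butoxy would do at the same place remains open in both read-outs. As far as these compounds go, with every step here within the scatter, it also remains open whether any change on this ring can shift either number at all.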